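Nitro in place of iodo: a second instance in the series

The source may report more compounds than this note shows. Statements on the series, on what has been measured and on what is new or still open speak of the compounds shown alone.

Of the compounds shown here, three share one core and have been measured in a functional assay on T98G cells (Homo sapiens) for cytotoxicity, read by MTT assay, with a stated time of 48 h; on this read-out higher numbers stand for weaker inhibition and lower numbers for stronger inhibition. Compound 1 `C/C(=N\NC(=S)Nc1ccc(I)cc1)c1ccccn1` gives 64 nM. Compound 2 `C/C(=N\NC(=S)Nc1cccc(I)c1)c1ccccn1` gives 61 nM. Compound 3 `C/C(=N\NC(=S)Nc1ccc([N+](=O)[O-])cc1)c1ccccn1` gives 140 nM. Compound 1 and compound 2 have the same atoms joined differently; the difference between the two cores is not broken down here, and their two numbers lie within the scatter of each other, so no order between them is claimed. Among the measured compounds shown here, the one counted change among the measured compounds is nitro in place of iodo on an aromatic carbon, and it made a 2.2-fold higher number from compound 1 to compound 3 (0.34 log units; beyond the scatter).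

Compound 4 `C/C(=N\NC(=S)Nc1cccc([N+](=O)[O-])c1)c1ccccn1` has not yet been measured. It differs from compound 2 by nitro in place of iodo on an aromatic carbon. For the measured compounds named here, this is the same kind of change as the one leading to compound 3, not the same: in compound 3 the nitro stands para to a large group, in compound 4 it stands meta to a large group. Going by the values given here, only one measured instance of this change exists, so any expectation rests on that single step and carries the uncertainty of a different placement. In this assay, among the compounds with values here, the step from compound 2 to compound 4 is expected to be a 2.1-fold higher number from compound 2 to compound 4 (0.33 log units; beyond the scatter), resting on the one measured step of this kind, a 2.2-fold higher number from compound 1 to compound 3 (0.34 log units; beyond the scatter). Compound 4 is therefore estimated at 130 nM in this assay, with an expected range from 60 nM to 280 nM.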

Compound 4, half-maximal inhibitory concentration: 140 nM
For compound 4 the middle estimate is 1.1-fold (0.03 log units) below the measured one, and the stated range covers the measured number.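

In this assay, nitro in place of iodo gave a 2.3-fold higher number from compound 2 to compound 4 (0.36 log units; beyond the scatter) and so repeated the earlier step in size, with the two instances agreeing as follows: the same change on two cores in this assay, a 2.2-fold higher number (0.34 log units; beyond the scatter) from compound 1 to compound 3 and a 2.3-fold higher number (0.36 log units; beyond the scatter) from compound 2 to compound 4, 1.0-fold (0.02 log units) apart, within the scatter of two such steps.

So in this series the change can be carried from the core of compound 1 to the core of compound 2 as a modest, roughly constant step toward weaker inhibition, and the difference in placement on the aromatic ring leaves no readable mark on its size. This rests on two steps only, both starting from iodo, both on closely related isomeric cores and both read in one cell assay, so it gives no basis for a general rule on other cores or other read-outs, and it says nothing on why the step has this size.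

The compounds shown leave open whether the same constancy would hold for other groups on the aromatic ring, such as an amine, a carboxylic acid, a nitrile or trifluoromethyl, in place of iodo. They also leave open how the step would behave with a longer chain in place of the methyl group of the shared core.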